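From 2-Methylphenoxy to Chloro on the Shared Core

This account rests on a few compounds, and the source may have more. Where it says the series, first, only, none or still open, it means among the compounds named here.

Compound 1, `Cc1nnsc1CO/N=C/c1c(C)nn(C)c1Oc1ccc(I)cc1`: 43800 nM
Compound 2, `CCCc1nnsc1CO/N=C/c1c(C)nn(C)c1Oc1ccccc1C`: 15700 nM

Of the compounds shown here, two have been measured in a functional assay on HCT-116 cells (Homo sapiens) for inhibition, read by MTT assay, with a stated time of 48 h; a lower number here means a stronger inhibitor, a higher number a weaker inhibitor. Compound 1 gives 43800 nM in this assay, and compound 2 gives 15700 nM. Compound 2 holds the lower of the two numbers; its nearest neighbour, compound 1, sits at a higher value, a gap beyond the usual scatter. For the measured compounds named here, the two compounds differ in more than one place, so their values show this difference and no single step.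

Compound 3, `CCCc1nnsc1CO/N=C/c1c(C)nn(C)c1Cl`, has not yet been measured. It differs from compound 2 in one place: chloro in place of 2-methylphenoxy on an aromatic carbon. No measured step of this kind exists among these compounds, so the expectation rests on the size of the change alone: a large group of compound 2 is replaced by a much smaller one. Compound 3 is therefore expected to be a weaker inhibitor, with an expected step of a 2.5-fold higher number from compound 2 to compound 3 (0.41 log units; beyond the scatter). Compound 3 is estimated at 40000 nM, with a range from 12000 nM to 130000 nM.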

Compound 3, half-maximal inhibitory concentration: > 50000 nM
Compound 3 ended at the assay's limit; the forecaster's own chance of this, stated with the estimate: 25%; middle value at least 1.2-fold (0.09 log units) away from the limit.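

For the compounds shown here, this is the only measured step at this position, the aromatic carbon that bears 2-methylphenoxy in compound 2, and it shows that the position is not indifferent to what sits there. In this assay, chloro in place of 2-methylphenoxy gives an at least 3.1-fold higher number from compound 2 to compound 3 (0.50 log units; beyond the scatter), so the smaller group, without the six-membered aromatic ring, goes with weaker inhibition. For compound 3, > 50000 nM is a limit of the assay and not a number, so the step has a lower bound but no known full size: the limit of > 50000 nM in this assay, at which 1 of the 3 values shown sits.

The compounds shown cannot separate the loss of the aromatic ring from the arrival of chloro. Methoxy or an amine at this position, or phenoxy without its methyl group, would each test a different part of that question.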